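This account rests on a few compounds, and the source may have more. Where it says the series, first, only, none or still open, it means among the compounds named here.

Measured so far:

compound 1, `CCCCCN(C1=NCCN1)c1c(Br)cccc1Br`: 11
compound 2, `CC(C)N(C1=NCCN1)c1c(Br)cccc1Br`: 11.2
compound 3, `Brc1cccc(Br)c1N(Cc1ccccc1)C1=NCCN1`: 10.4

All three were studied in a physicochemical assay for acid dissociation. Compound 1 gives the second highest of the three numbers. Its nearest neighbour is compound 2, and the step of a number 0.20 log units higher from compound 1 to compound 2 (within the scatter) lies within the scatter, so these two compounds cannot be told apart. The step of a number 0.60 log units lower from compound 1 to compound 3 (beyond the scatter) is a modest drop beyond the scatter, and the step of a number 0.80 log units lower from compound 2 to compound 3 (beyond the scatter) points the same way.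

Compound 4, `Brc1cccc(Br)c1N(Cc1cccs1)C1=NCCN1`, is not yet measured in this assay. It differs from compound 1 as follows: thiophen-2-yl in place of butyl on a saturated chain carbon bound to a nitrogen on an aromatic ring. This change has a close parallel in the step from compound 1 to compound 3, where an aromatic ring also replaced butyl at the same place and the number fell by a number 0.60 log units lower from compound 1 to compound 3 (beyond the scatter). The change to compound 4 likewise puts a five-membered aromatic ring where the butyl chain was, so a step of similar size and direction is expected, namely a number 0.50 log units lower from compound 1 to compound 4 (beyond the scatter). Compound 4 is therefore estimated to give 10.5 in this assay, with a likely range from 10.1 to 10.9. Among the compounds with values here, only one measured step bears on this, so the estimate rests on a single comparison.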

Compound 4, acid dissociation constant: 10.5
Compound 4: middle estimate and measured number agree at the digits printed; the measured number falls inside the stated range.
By their numbers in this assay, from the lowest: compounds 3 and 4 (each within the scatter of the next); then compounds 1 and 2 (each within the scatter of the next).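

In this assay, thiophen-2-yl in place of butyl gives a number 0.50 log units lower from compound 1 to compound 4 (beyond the scatter) and (thiophen-2-yl)methyl in place of isopropyl gives a number 0.70 log units lower from compound 2 to compound 4 (beyond the scatter) at this place, so the drop seen earlier with phenyl is no longer tied to that single ring: among these compounds, both aromatic groups stand below both chain groups, and no compound goes against this. Thiophen-2-yl in place of phenyl gives a number 0.10 log units higher from compound 3 to compound 4 (within the scatter) and thus brings no readable difference, even though a five-membered ring with a sulfur atom replaces a phenyl ring. No measurement here explains why an aromatic ring at this place goes with a lower number.

On these data alone, whether cyclohexyl, a saturated carbon ring, would fall with compound 3 and compound 4 or with compound 1 and compound 2 stays open, so the compounds cannot yet separate the effect of having a ring from that of having an aromatic one. Equally open, as far as these compounds go, is what a pyridyl ring, or a phenyl ring carrying an amine or a carboxylic acid, would do to the number at this place.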